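The compounds below may be only part of what the source reports. "The series", "measured", "known", "first", "only" and "open" are said of these compounds alone.

The series shares one core, an alkyne-linked aryl on a fused thiazole. Compound 1 `Cc1cccc(C#Cc2nc3c(s2)C(=O)NCC3)c1` carries a lactam in that core, and in an assay on HEK293 cells for positive allosteric modulation of metabotropic glutamate receptor 5 (Homo sapiens), read by FLIPR, with a stated time of 1 h (on this read-out higher numbers stand for an effect only at larger amounts of compound and lower numbers for an effect already at smaller amounts), compound 1 reaches only the limit > 10000 nM, so no number is known for it (the limit of > 10000 nM in this assay, at which 1 of the 3 values shown sits). Compound 2 `CN1CCc2nc(C#Cc3ccccc3)sc2C1` carries a basic methylamine in the saturated ring instead, and in this assay compound 2 gives 34 nM. Among the compounds with values here, compound 3 `O=C(C1CC12CCC2)N1CCc2nc(C#Cc3ccccc3)sc2C1` replaces that methyl with a spirocyclic acyl group, and in this assay compound 3 gives 3.9 nM, the lowest number of the two that are known; the one measured step, an 8.7-fold lower number from compound 2 to compound 3 (0.94 log units; beyond the scatter), shows that acylation of the ring nitrogen is what brings the number down.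

Compound 4 `O=C(C1CCCCO1)N1CCc2nc(C#Cc3ccccc3)sc2C1` keeps that acylated nitrogen and differs from compound 3 only in the group on the carbonyl carbon: a group of 6 heavy atoms (5 carbon, 1 oxygen; one six-membered non-aromatic ring with 1 hetero atom) in place of a group of 6 heavy atoms (6 carbon; one three-membered non-aromatic ring of carbon only, one four-membered non-aromatic ring of carbon only), on a carbonyl carbon. Within the data shown here, no measured step compares two different acyl substituents, so the single step from compound 2 to compound 3 says only that an acyl group helps, not how much its shape matters. With the amide kept, a step within the scatter, or at most a small one in either direction, is the expectation.

Compound 4 is therefore expected to give about 6 nM, most likely between 2 nM and 20 nM. The estimated step of a 1.5-fold higher number from compound 3 to compound 4 (0.19 log units; within the scatter) is expected to stay within the usual scatter.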

Compound 4, half-maximal effective concentration: 320 nM
Beside the measured number, compound 4's estimate is 53-fold (1.73 log units) below it, outside the stated range (above it).
By their numbers in this assay, from the lowest: compound 3; then compound 2; then compound 4. At a limit, above all of these: compound 1.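

On a carbonyl carbon whose other neighbours are an amide-type nitrogen in a ring, exchanging the spirocyclic group for oxan-2-yl gives an 82-fold higher number from compound 3 to compound 4 (1.91 log units; beyond the scatter) in this assay, so the group on the carbonyl carbon strongly influences the number, even with the amide kept. Acylation of the ring nitrogen also proves not to lower the number in itself: an 8.7-fold lower number from compound 2 to compound 3 (0.94 log units; beyond the scatter) runs in the opposite direction to a 9.4-fold higher number from compound 2 to compound 4 (0.97 log units; beyond the scatter), and the outcome of replacing the methyl depends on which acyl group enters. Nothing measured here explains the difference between the oxan-2-yl group and the spirocyclic group.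

The compounds shown leave open whether the higher number of compound 4 goes with the oxygen in its ring or with the ring itself, as oxan-2-yl differs from the spirocyclic group in both; a cyclohexyl group, with its ring of carbon only, would separate the two. They also leave open where oxan-3-yl and oxan-4-yl, which place that oxygen differently in the ring, would fall.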